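Swapping a cyclopropyl for a 4-iodophenyl on the amine

The source may hold more compounds than are shown below. What is called first, only, known or untested is meant among the compounds shown, and "the series" means these compounds.

The shared core carries an amine whose substituent is the only thing that varies here. Compound 1 `O=C1C(NC2CC2)=CC(=O)c2c1nc1n2[C@H]2OC[C@@H](O)[C@H]2OC1` bears a cyclopropyl on that nitrogen. In a functional assay on MCF7 cells (Homo sapiens) for inhibition, read by sulforhodamine B assay (a higher number here means a weaker inhibitor, a lower number a stronger inhibitor), compound 1 returns only a limit of the assay, > 16000 nM, so no number is known for it. Compound 2 `CCc1ccc(NC2=CC(=O)c3nc4n(c3C2=O)[C@H]2OC[C@@H](O)[C@H]2OC4)cc1` carries a 4-ethylphenyl there and gives 960 nM. Compound 3 `CCOc1ccccc1NC1=CC(=O)c2nc3n(c2C1=O)[C@H]1OC[C@@H](O)[C@H]1OC3` carries a 2-ethoxyphenyl and also gives only a limit, > 4000 nM. Among the compounds with values here, the one measured step, an at least 4.1-fold higher number from compound 2 to compound 3 (0.61 log units; beyond the scatter), compares two aromatic groups and so does not directly test the change at hand.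

Compound 4 `O=C1C(Nc2ccc(I)cc2)=CC(=O)c2c1nc1n2[C@H]2OC[C@@H](O)[C@H]2OC1` differs from compound 1 by 4-iodophenyl in place of cyclopropyl on an amine nitrogen. Compound 2 shows that an aromatic group at this position can be compatible with measurable inhibition, while the cyclopropyl of compound 1 sits at the limit (the limit of > 16000 nM in this assay, at which 1 of the 3 values shown sits). Because compound 2 gives 960 nM in this assay with a ring of the same kind, compound 4 is expected to reach about 1200 nM, between 400 nM and 5000 nM. That would be an expected improvement of an at least 13-fold lower number from compound 1 to compound 4 (1.12 log units; beyond the scatter).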

Compound 4, half-maximal inhibitory concentration: 3890 nM
The estimate for compound 4 lay 3.2-fold (0.51 log units) below the measured number, and the stated range covers the measured number.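

Within the data shown here, replacing the cyclopropyl with a 4-iodophenyl on the amine nitrogen is the first direct test here of an aromatic ring against a three-membered non-aromatic ring, and in this assay it gives an at least 4.1-fold lower number from compound 1 to compound 4 (0.61 log units; beyond the scatter). As far as these compounds go, the true size of this step stays unknown, because one end of it is not a number: the limit of > 16000 nM in this assay, at which 1 of the 4 values shown sits. Compound 2 gives 960 nM and compound 4 gives 3890 nM, so a measured number at this position is not confined to the 4-ethylphenyl.

Compound 3, with its 2-ethoxyphenyl, returns only a limit, > 4000 nM, so an aromatic ring alone does not ensure a measured number. From the compounds shown here alone, how a plain phenyl, a 4-chlorophenyl or a longer chain such as n-butyl would behave on this nitrogen remains open.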